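The source may report more compounds than this note shows. Statements on the series, on what has been measured and on what is new or still open speak of the compounds shown alone.

Measured in a functional assay on HeLa cells (Homo sapiens) for antiproliferative activity, read by MTT assay, with a stated time of 48 h; a lower number here means a stronger inhibitor, a higher number a weaker inhibitor:
- compound 1 `COc1ccc(N(C)c2ccnc(Cl)n2)cc1OCCC[Se]C#N`: 4710 nM
- compound 2 `COc1ccc(N(C)c2ccnc(Cl)n2)cc1OCCCC[Se]C#N`: > 10000 nM

For compound 2, the result > 10000 nM is a limit of the assay and not a number. The data so far contain (the limit of > 10000 nM in this assay, at which 1 of the 2 values shown sits).

Compound 3 `COc1ccc(N(C)c2ccnc(Cl)n2)cc1OCCCCC[Se]C#N` has not yet been measured. Its structure differs from the one before it by a group of 4 heavy atoms (2 carbon, 1 nitrogen, 1 selenium; no ring) in place of a group of 3 heavy atoms (1 carbon, 1 nitrogen, 1 selenium; no ring), on a saturated chain carbon, four bonds along the chain from an oxygen on an aromatic ring.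

Among the compounds with values here, only one measured step bears on this change. It is the same kind of exchange, made on a saturated chain carbon three bonds along the chain from an oxygen on an aromatic ring: an at least 2.1-fold higher number from compound 1 to compound 2 (0.32 log units; beyond the scatter). Given that single step, a further modest move toward a higher number, meaning a weaker inhibitor, is expected in this assay.

The estimated change is a step that the limit leaves unreadable from compound 2 to compound 3. For compound 3 the expected value is 15000 nM, with an expected range of 6000 nM to 40000 nM.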

Compound 3, half-maximal inhibitory concentration: > 10000 nM
Compound 3: a limit, no number; the forecaster's own chance of this, stated with the estimate: 70%; the middle value lies beyond the limit too.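

In this assay, a chain longer still does not bring back a readable number, so the weakening seen with the first added chain carbon is not undone at this next position: the result is an at least 2.1-fold higher number from compound 1 to compound 3 (0.32 log units; beyond the scatter). Going by these compounds, the value for compound 3 is a limit of the assay and not a number, so the step from compound 2 cannot be read, and whether the added carbon weakens the compound further stays unknown. The longer compounds now share one ceiling: the limit of > 10000 nM in this assay, at which 2 of the 3 values shown sit.

On these data alone, whether a shorter chain would give a lower number than compound 1 remains open. So does what an amine or a carboxylic acid would do at the chain end, in place of the group carrying selenium and the nitrile.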